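A few compounds are considered here, and "the series" means these few. Any claim that something is new, unique, unknown or untested is made for them only; others in the source may bear on it.

Measured compounds:
compound 1 `COc1ccc(/C=N/NC(=O)Nc2ccc(Oc3ccnc4cc(OCCCN5CCCCC5)c(OC)cc34)c(F)c2)c(OC)c1`: in a functional assay on MKN-45 cells (Homo sapiens) for cytotoxicity, read by MTT assay, with a stated time of 72 h (a higher number here means a weaker inhibitor, a lower number a stronger inhibitor), compound 1 gives 1990 nM
compound 2 `COc1cc2c(Oc3ccc(NC(=O)N/N=C/c4cccs4)cc3F)ccnc2cc1OCCCN1CCCCC1`: in this assay compound 2 gives 740 nM

Compound 2 holds the lowest of the two numbers; the step of a 2.7-fold lower number from compound 1 to compound 2 (0.43 log units; beyond the scatter) separates it from compound 1 and lies beyond the scatter, though it is modest in size.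

Compound 3 `COc1cc2c(Oc3ccc(NC(=S)N/N=C/c4ccc(Cl)cc4)cc3F)ccnc2cc1OCCCN1CCCCC1` differs from compound 2 by a group of 12 heavy atoms (8 carbon, 2 nitrogen, 1 sulfur, 1 chlorine; one six-membered aromatic ring of carbon only) in place of a group of 10 heavy atoms (6 carbon, 2 nitrogen, 1 oxygen, 1 sulfur; one five-membered aromatic ring with 1 hetero atom), on a nitrogen on an aromatic ring. For the measured compounds named here, the only measured step, a 2.7-fold lower number from compound 1 to compound 2 (0.43 log units; beyond the scatter), concerned the aryl group on the carbon with a double bond to nitrogen, so it bears on the aryl part of the present change; the rest of the change has no measured counterpart in this set. That one step was modest, and the present change also exchanges one aryl group for another, so in this assay a step of at most modest size is expected, with no clear direction.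

Compound 3 is therefore expected to give about 700 nM, within a range of 250 nM to 2500 nM. This estimate corresponds to a 1.1-fold lower number from compound 2 to compound 3 (0.02 log units; within the scatter), which is expected to lie within the scatter.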

Compound 3, half-maximal inhibitory concentration: 500 nM
Estimate against measurement, compound 3: 1.4-fold (0.15 log units) above; the range from low to high includes it.
By their numbers in this assay, from the lowest: compounds 3 and 2 (each within the scatter of the next); then compound 1.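

In this assay, the change on the nitrogen on an aromatic ring replaces two features at once: the five-membered aromatic ring with 1 hetero atom gives way to a chlorine-bearing six-membered aromatic ring of carbon only, and the carbonyl oxygen gives way to sulfur. Together these amount to a 1.5-fold lower number from compound 2 to compound 3 (0.17 log units; within the scatter), whereas the earlier exchange of one aryl group for another, with the carbonyl kept, gave a 2.7-fold lower number from compound 1 to compound 2 (0.43 log units; beyond the scatter). The new result therefore shows that this combined change to both the linking group and the aryl group does not separate compound 3 from compound 2 in this assay, and nothing measured here accounts for that result.

The compounds shown leave open how the two parts of the change act on their own, as neither the thiocarbonyl with the five-membered ring nor the carbonyl with the chlorine-bearing ring appears among them. Going by these compounds, it also remains open whether an amine, a carboxylic acid or a longer chain on that aromatic ring would shift the number in this assay beyond the scatter.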